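Swapping the ester group on a shared cyclohexyl anilide core

A few compounds are considered here, and "the series" means these few. Any claim that something is new, unique, unknown or untested is made for them only; others in the source may bear on it.

Compound 3 `O=C(/C=C/c1ccccc1)OC1(C(=O)Nc2ccc([N+](=O)[O-])cc2)CCCCC1` gives 50.5 nM in a functional assay on NFS-60 cells (Mus musculus) for inhibition, read by MTT assay, with a stated time of 72 h; a lower number here means a stronger inhibitor, a higher number a weaker inhibitor. Among the three measured compounds it stands second highest. Its nearest neighbour is compound 1 `O=C(OC1(C(=O)Nc2ccc([N+](=O)[O-])cc2)CCCCC1)c1ccc(C(F)(F)F)cc1`, which in this assay gives 26 nM; the step of a 1.9-fold higher number from compound 1 to compound 3 (0.29 log units; within the scatter) is within the scatter. Furthest away is compound 2 `CCOC(=O)c1ccccc1C(=O)OC1(C(=O)Nc2ccc([N+](=O)[O-])cc2)CCCCC1`, which in this assay gives 488 nM, a higher number than compound 3 beyond the scatter.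

Compound 4 `O=C(OC1(C(=O)Nc2ccc([N+](=O)[O-])cc2)CCCCC1)C(O)c1ccccc1` differs from compound 3 in one place: hydroxy(phenyl)methyl in place of 2-phenylethenyl on a carbonyl carbon. Going by the values given here, the only measured step at this position, a 1.9-fold higher number from compound 1 to compound 3 (0.29 log units; within the scatter), was within the scatter, so one change of the group on the carbonyl carbon left the number nearly unmoved. Among the compounds with values here, no measured step brings in the hydroxy(phenyl)methyl group, and compound 2 shows that a different group at the same place can raise the number well beyond the scatter. With that spread in view, a modest rise is expected from compound 3 to compound 4, a 1.8-fold higher number from compound 3 to compound 4 (0.25 log units; within the scatter). Compound 4 is estimated at 90 nM, with a range from 25 nM to 320 nM.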

Compound 4, half-maximal inhibitory concentration: 7.8 nM
For compound 4 the middle estimate is 12-fold (1.06 log units) above the measured one; the measured number lies below the stated range.
By their numbers in this assay, from the lowest: compound 4; then compounds 1 and 3 (each within the scatter of the next); then compound 2.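

Hydroxy(phenyl)methyl on the carbonyl carbon lowers the number beyond the scatter against both earlier groups, 2-phenylethenyl (a 6.5-fold lower number from compound 3 to compound 4 (0.81 log units; beyond the scatter)) and 4-(trifluoromethyl)phenyl (a 3.3-fold lower number from compound 1 to compound 4 (0.52 log units; beyond the scatter)). Until now, this position had shown only a step within the scatter and the higher number of compound 2, so a change here can also give a clearly stronger inhibitor. The group that enters keeps the six-membered aromatic ring and has the same number of heavy atoms as 2-phenylethenyl, but it loses the double bond and adds a hydrogen-bond donor and acceptor, and nothing at hand explains why the number falls.

The compounds shown leave open whether the hydroxy group or the loss of the double bond matters more. A benzyl, methoxy(phenyl)methyl or amino(phenyl)methyl group at the same place would help to separate the two.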